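The compounds below may be only part of what the source reports. "The series", "measured", "known", "first", "only" and "open" are said of these compounds alone.

Measured compounds:
compound 1, `Cc1ccc(C(=O)CCc2nnc(-c3ccccc3Cl)o2)c(C)c1`, in a functional assay on the whole organism (strain Wistar) for inhibition, with Rattus norvegicus as the target, with stated times of 30 min and 2 h, at a dose of 20 mg/kg by the oral route (a higher number here means more inhibition at the dose given (going by the name of the read-out), a lower number less inhibition), gives 33.5%
compound 2, `Cc1ccc(C(=O)CCc2nnc(-c3ccc([N+](=O)[O-])cc3)o2)c(C)c1`, in this assay gives 40%

Within the data shown here, compound 2 stands within the scatter of compound 1, the only other number in this assay, so the two give no order between them. Compound 3, `COc1ccc(-c2nnc(CCC(=O)c3ccc(C)cc3C)o2)cc1`, follows from compound 2 by methoxy in place of nitro on an aromatic carbon. Among the measured compounds shown here, no step of this kind has been measured, so the size of its effect is unknown; with the two measured numbers so close together, no step beyond the scatter is expected in either direction. Compound 3 is estimated at 38%, range 24% to 52%, an expected step of a number 2 percentage points lower from compound 2 to compound 3 (within the scatter).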

Compound 3, a percentage reported as inhibition, in the whole organism at one dose (the size of the read-out at that dose, not a potency): 62.7%
Compound 3: middle estimate off by 24.7 percentage points, on the low side; the whole stated range lies below it.
By their numbers in this assay, from the lowest: compounds 1 and 2 (each within the scatter of the next); then compound 3.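

In this assay the substituent on this aromatic ring now produces a step beyond the scatter: methoxy in place of nitro, para to a large group, gives (a number 22.7 percentage points higher from compound 2 to compound 3 (beyond the scatter)), and 4-methoxyphenyl in place of 2-chlorophenyl gives (a number 29.2 percentage points higher from compound 1 to compound 3 (beyond the scatter)). Compound 1 and compound 2 alone gave no order, so this position proved sensitive to the group it carries only with compound 3. Nothing measured here bears on the reason for these steps.

Still open, from the compounds shown here alone, is whether a hydroxyl or an amine in the same place matches methoxy, and whether a longer chain in the linker of the shared core keeps the higher number.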